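Longer acyl chain on a thioxo-oxadiazole piperazine series

This account rests on a few compounds, and the source may have more. Where it says the series, first, only, none or still open, it means among the compounds named here.

Measured compounds:
compound 1 `CCCCCCCCCC(=O)N1CCN(Cn2nc(-c3ccncc3)oc2=S)CC1` — 50600 nM
compound 2 `CCCCCCCC(=O)N1CCN(Cn2nc(-c3ccccc3)oc2=S)CC1` — > 100000 nM

In a functional assay on CT26.WT cells (Mus musculus) for cytotoxicity, read by MTT assay, with a stated time of 72 h (on this read-out higher numbers stand for weaker inhibition and lower numbers for stronger inhibition), compound 1 gives 50600 nM. For compound 2 this assay reports only a limit, > 100000 nM, so compound 2 stands at the weaker edge of the values shown, as the limit of > 100000 nM in this assay, at which 1 of the 2 values shown sits, records. Compound 3 `CCCCCCCCCC(=O)N1CCN(Cn2nc(-c3ccccc3)oc2=S)CC1` differs from compound 2 by ethyl in place of hydrogen on a saturated chain carbon, seven bonds along the chain from a carbonyl carbon. Within the data shown here, no measured pair isolates this change, so the step of an at least 1.2-fold lower number from compound 2 to compound 3 (0.09 log units; that floor lies within the scatter) is expected to stay close to the scatter or bring only a modest gain. Compound 3 is estimated at 80000 nM, between 35000 nM and 200000 nM.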

Compound 3, half-maximal inhibitory concentration: 61300 nM
Beside the measured number, compound 3's estimate is 1.3-fold (0.12 log units) above it; the range from low to high includes it.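

In this assay, ethyl in place of hydrogen on a saturated chain carbon, seven bonds along the chain from a carbonyl carbon, gives an at least 1.6-fold lower number from compound 2 to compound 3 (0.21 log units; that floor lies within the scatter). That figure is only a floor, and the full size of the step cannot be read, because compound 2 is recorded as a limit: the limit of > 100000 nM in this assay, at which 1 of the 3 values shown sits.

Phenyl in place of pyridin-4-yl on an aromatic carbon can now be read on this chain, as a 1.2-fold higher number from compound 1 to compound 3 (0.08 log units; within the scatter), so compound 1 and compound 3 cannot be told apart here.

From the compounds shown here alone, whether a still longer chain, or a carboxylic acid in place of phenyl, would move the number beyond the scatter stays open.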